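Moving the pyridine nitrogen in the ester of compound 1

This account rests on a few compounds, and the source may have more. Where it says the series, first, only, none or still open, it means among the compounds named here.

- compound 1 `CCCC1C(C(=O)OCc2ccccn2)=C(C)NC2=C1C(=O)CCC2` gives 2.6
- compound 2 `CC1=C(C(=O)OCc2ccccn2)C(c2ccc(Br)cc2)C2=C(CCCC2=O)N1` gives 2.42
- compound 3 `CC1=C(C(=O)OCc2ccccn2)C(c2ccc(C#N)cc2)C2=C(CCCC2=O)N1` gives 1.73

In a physicochemical assay for lipophilicity, measured as octanol-water partition (a higher number here means a more lipophilic compound, a lower number a more polar compound), compound 1 stands level with compound 2: a number 0.18 log units lower from compound 1 to compound 2 (within the scatter). Compound 3 stands apart: a number 0.87 log units lower from compound 1 to compound 3 (beyond the scatter). Compound 4 `CCCC1C(C(=O)OCc2cccnc2)=C(C)NC2=C1C(=O)CCC2` remains unmeasured. Its change is pyridin-3-yl in place of pyridin-2-yl on a saturated chain carbon bound to an oxygen next to a carbonyl group. Among the compounds with values here, no measured step touches this place. The nearest guide is only indirect, since the larger steps, such as a number 0.69 log units lower from compound 2 to compound 3 (beyond the scatter), exchange different groups elsewhere, while here the same atoms are joined differently. The expected step is a number 0.10 log units lower from compound 1 to compound 4 (within the scatter), so no shift beyond the scatter is anticipated. Compound 4 is estimated at 2.5, with an expected range of 2.15 to 2.85.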

Compound 4, partition coefficient: 2.23
Estimate against measurement, compound 4: 0.27 log units above, and the stated range covers the measured number.
By their numbers in this assay, from the lowest: compound 3; then compounds 4, 2 and 1 (each within the scatter of the next, the first and the last beyond it).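

The ester position now has its first reading in this assay: pyridin-3-yl in place of pyridin-2-yl gives a number 0.37 log units lower from compound 1 to compound 4 (beyond the scatter) and so exceeds the scatter. Merely rejoining the same atoms on the saturated chain carbon bound to an oxygen next to a carbonyl group therefore registers here, with heavy-atom and hydrogen-bond counts unchanged. No supporting evidence accounts for this step.

Still open, going by these compounds, is whether the change carries over to the 4-bromophenyl and 4-cyanophenyl compounds. On these data alone, the placing of pyridin-4-yl or plain phenyl at this position is also open.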